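The source may report more compounds than this note shows. Statements on the series, on what has been measured and on what is new or still open speak of the compounds shown alone.

Measured so far in an assay on HEK293 cells for inhibition of N-acylethanolamine-hydrolyzing acid amidase (Rattus norvegicus), read by LC-MS, with a stated time of 30 min; on this read-out lower numbers stand for stronger inhibition and higher numbers for weaker inhibition:
compound 1 `O=C(CCCCCc1cccc(I)c1)N1CCOC1=O` gives 3120 nM
compound 2 `CSc1cccc(CCCCCC(=O)N2CCOC2=O)c1` gives 12800 nM
compound 3 `O=C(CCCCCc1ccc(O)c(F)c1)N1CCOC1=O` gives 160 nM

Compound 2 stands at the highest number of the three in this assay. The nearest is compound 1, and the gap to it is beyond the scatter; the furthest is compound 3, whose number lies far lower, again beyond the scatter. Among the compounds with values here, compound 3 carries a different set of groups on its ring and no single-point step connects it to compound 2, so only its value is known.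

Compound 4 `COc1cccc(CCCCCC(=O)N2CCOC2=O)c1` differs from compound 2 by methoxy in place of methylsulfanyl on an aromatic carbon. Within the data shown here, the one measured step that bears on this place is a 4.1-fold higher number from compound 1 to compound 2 (0.61 log units; beyond the scatter): a swap of one group for another at the same carbon, and it came out modest. Nothing measured shows methoxy itself at this position, so the direction of the new step is uncertain. The expectation is therefore a step of at most modest size, with a somewhat lower number taken as the working guess, a 1.8-fold lower number from compound 2 to compound 4 (0.26 log units; within the scatter). Compound 4 is expected to give about 7000 nM in this assay, with a range from 2500 nM to 20000 nM.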

Compound 4, half-maximal inhibitory concentration: 16300 nM
Beside the measured number, compound 4's estimate is 2.3-fold (0.37 log units) below it; measured number inside the range.
By their numbers in this assay, from the lowest: compound 3; then compound 1; then compounds 2 and 4 (each within the scatter of the next).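

In this assay, methoxy in place of methylsulfanyl on this aromatic carbon gives a 1.3-fold higher number from compound 2 to compound 4 (0.10 log units; within the scatter) and so leaves the two groups indistinguishable here, although each has two heavy atoms and one swaps sulfur for oxygen. The measured separation at this carbon now lies between iodo and both of these groups, with a 5.2-fold higher number from compound 1 to compound 4 (0.72 log units; beyond the scatter) in the assay and a 4.1-fold higher number from compound 1 to compound 2 (0.61 log units; beyond the scatter) in the earlier comparison, so the gap to iodo is no longer tied to methylsulfanyl alone. No measurement at hand accounts for the match between methoxy and methylsulfanyl or for the gap to iodo.

The compounds shown leave open whether an amine, a carboxylic acid or a hydroxy group on this carbon would depart from the values of these three compounds, and whether a longer or shorter chain would change the ranking of iodo, methoxy and methylsulfanyl. Within the data shown here, they also leave open what each group on the ring of compound 3 contributes to its value of 160 nM in this assay on its own, as no single-group step connects that compound to the others.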